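How Well Do Cells Tolerate Compound 3?

The compounds below may be only part of what the source reports. "The series", "measured", "known", "first", "only" and "open" are said of these compounds alone.

Compound 1 `O=C(COC(=O)c1ccc([N+](=O)[O-])o1)NCC1CCCO1`: > 100000 nM
Compound 2 `CC(C)(C)N(CCC(=O)c1ccccc1)C(=O)COC(=O)c1ccc([N+](=O)[O-])o1`: "not active" (no number reported)

Both compounds were tested in an ADME assay on HEK-293T cells (Homo sapiens) for cytotoxicity, read by MTT assay, with a stated time of 3 days; a lower number here means that less compound is tolerated, a higher number that more compound is tolerated. Compound 1 gives > 100000 nM, which is a limit of the assay and not a number. Compound 2 has no single number at all, since it is recorded only as "not active" (no number reported). Neither compound therefore offers an exact concentration for comparison.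

The next structure is compound 3 `COc1ccc(CN(C(=O)COC(=O)c2ccc([N+](=O)[O-])o2)C(C)(C)C)cc1`. The change is 4-methoxyphenyl in place of benzoylmethyl on a saturated chain carbon bound to an amide-type nitrogen, which puts 4-methoxyphenyl in place of benzoylmethyl on a saturated chain carbon bound to an amide-type nitrogen. The rest of the molecule stays the same.

Among the compounds with values here, no measured pair of compounds shows what a single change does here, so any forecast is uncertain. With compound 2 recorded as "not active" (no number reported), the expectation is no step beyond the usual scatter in this assay, and so no clear move in either direction. Compound 3 may well be reported only as a limit too. If a number is obtained, compound 3 has an estimated value of 70000 nM, with an expected range from 20000 nM to 200000 nM.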

Compound 3, half-maximal cytotoxic concentration: > 100000 nM
Compound 3: a limit, no number (the forecaster's own chance of this, stated with the estimate: 65%); middle value at least 1.4-fold (0.15 log units) from the limit.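

In this assay compound 3 gives > 100000 nM as a limit and not a number. Within the data shown here, no step from compound 2 to compound 3 can be read, because neither compound has an exact number: the limit of > 100000 nM in this assay, at which 2 of the 3 values shown sit.

The compounds shown leave open at what concentration, if any, each one harms these cells, and whether benzoylmethyl and 4-methoxyphenyl differ in this respect.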